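A carboxy group enters the aryl ether arm

This account rests on a few compounds, and the source may have more. Where it says the series, first, only, none or still open, it means among the compounds named here.

Among the measured compounds shown here, compound 2 `COCOc1ccc(CN(Cc2ccc(C(C)(C)C)cc2)Cc2cc3cc(C)ccc3[nH]c2=O)cc1` is the one compound of the three for which a toxicity assay on MDCK cells (Canis lupus familiaris) for cytotoxicity, read by crystal violet staining, with a stated time of 48 h (a higher number here means that more compound is tolerated, a lower number that less compound is tolerated), reports a number: in this assay compound 2 gives 6400 nM. Compound 1 `Cc1ccc2[nH]c(=O)c(CN(CCCO)Cc3ccc(C(C)(C)C)cc3)cc2c1` reaches only a limit in this assay, > 10000 nM. Compound 3 `CCc1ccc2[nH]c(=O)c(CN(Cc3ccc(OCOC)cc3)Cc3ccc(C(C)(C)C)cc3)cc2c1` likewise reaches only a limit, > 10000 nM. Both measured steps, an at least 1.5-fold lower number from compound 1 to compound 2 (0.19 log units; that floor lies within the scatter) and an at least 1.5-fold higher number from compound 2 to compound 3 (0.19 log units; that floor lies within the scatter), are therefore floors rather than exact sizes, each resting on a limit (the limit of > 10000 nM in this assay, at which 2 of the 3 values shown sit), and neither is shown to lie beyond the scatter.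

Compound 4 `Cc1ccc2[nH]c(=O)c(CN(Cc3ccc(OCC(=O)O)cc3)Cc3ccc(C(C)(C)C)cc3)cc2c1` differs from compound 2 by carboxy in place of methoxy on a saturated chain carbon bound to an oxygen on an aromatic ring. Neither measured step touches that place: one exchanges the whole arm on the amine nitrogen, the other changes the core. With both measured steps within the scatter, no step beyond the scatter is expected here either, and the expected step is a 1.3-fold higher number from compound 2 to compound 4 (0.10 log units; within the scatter). Compound 4 is estimated at 8000 nM, within a range from 3500 nM to 20000 nM in this assay.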

Compound 4, half-maximal cytotoxic concentration: > 10000 nM
Compound 4: a limit, no number; the forecaster's own chance of this, stated with the estimate: 45%; middle value at least 1.2-fold (0.09 log units) away from the limit.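

This is the first change shown inside the 4-(methoxymethoxy)phenyl arm itself, where the earlier steps exchanged the whole arm or changed the core. In this assay, carboxy in place of methoxy on a saturated chain carbon bound to an oxygen on an aromatic ring gives an at least 1.5-fold higher number from compound 2 to compound 4 (0.19 log units; that floor lies within the scatter), so the compounds shown give no sign that this exchange lowers the number. Compound 4 reaches only a limit, and the step stays a floor rather than an exact size because the read-out stops there for most of the series: the limit of > 10000 nM in this assay, at which 3 of the 4 values shown sit.

The step from compound 1 to compound 4 cannot be read. From the compounds shown here alone, whether an amine or a longer chain ending in an ester at this place would give a number rather than a limit stays open.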